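Swapping Chloro for Methoxy on a Shared Core

This account rests on a few compounds, and the source may have more. Where it says the series, first, only, none or still open, it means among the compounds named here.

Compound 2, `Cc1c(NC(=O)OC(C)C)[n+]([O-])c2cc(Cl)ccc2[n+]1[O-]`: 100%
Compound 1, `COc1ccc2c(c1)[n+]([O-])c(C(=O)N=[N+]=[N-])c(C)[n+]2[O-]`: 94.5%

Of the compounds shown here, two have been measured in a functional assay on Ehrlich cells (Mus musculus) for cytotoxicity, read by trypan blue exclusion, with a stated time of 2 h, tested at 1 ug/mL; on this read-out lower numbers stand for a stronger effect and higher numbers for a weaker effect at the one concentration tested. Compound 2 gives 100%, and compound 1 gives 94.5%; the two numbers lie within the usual scatter of each other, so neither stands apart. Compound 3, `COc1ccc2c(c1)[n+]([O-])c(NC(=O)OC(C)C)c(C)[n+]2[O-]`, is not yet measured. It differs from compound 2 in one place: methoxy in place of chloro on an aromatic carbon. No measured pair differs by exactly this change, so nothing shown tells how large a step to expect. Compound 1 also carries a methoxy group and gives 94.5%, so a step beyond the scatter seems unlikely. For compound 3 the expected value is 97%, within 85% to 100%. This estimate means a step of a number 3 percentage points lower from compound 2 to compound 3 (within the scatter), expected to stay within the scatter.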

Compound 3, a percentage reported as activity, at one concentration (the size of the read-out at that concentration, not a potency): 100%
Compound 3: the middle estimate sits 3 percentage points below what was measured; the range from low to high includes it.
By their numbers in this assay, from the lowest: compounds 1, 2 and 3 (each within the scatter of the next).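

In this assay, methoxy in place of chloro on an aromatic carbon gives no change at the digits printed from compound 2 to compound 3 (within the scatter), so this swap at this position now has a direct reading. A second swap, a group of 7 heavy atoms in place of a group of 5 heavy atoms on an aromatic carbon, gives a number 5.5 percentage points higher from compound 1 to compound 3 (within the scatter). Nothing measured here bears on the reason for these results. Going by these compounds, whether an amine or a carboxylic acid at the methoxy position would give a step beyond the scatter stays open. So does which change to the shared core would give a stronger effect at this one concentration.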